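Benzyl in Place of Methyl on a Triazine Ether

This account rests on a few compounds, and the source may have more. Where it says the series, first, only, none or still open, it means among the compounds named here.

Measured so far:
compound 1, `CCCCNc1nc(N)nnc1OC`: 2040 nM
compound 2, `CCCC[C@H](CCO)Nc1nc(N)nnc1OC`: 5870 nM

In an assay on isolated protein for agonist activity at Toll-like receptor 8 (Homo sapiens) (on this read-out higher numbers stand for an effect only at larger amounts of compound and lower numbers for an effect already at smaller amounts), compound 1 gives 2040 nM and stands at the lowest of the two numbers, so it acts at the smaller amount of compound. Compound 2 gives 5870 nM, a higher number that lies beyond the scatter. Compound 3, `CCCCNc1nc(N)nnc1OCc1ccccc1`, is not yet measured. It differs from compound 1 by phenyl in place of hydrogen on a saturated chain carbon bound to an oxygen on an aromatic ring. For the measured compounds named here, no measured pair shows what such a change does here, so the step of a 1.5-fold higher number from compound 1 to compound 3 (0.17 log units; within the scatter) is expected to be small, in no clear direction, and within the scatter. Compound 3 is estimated at 3000 nM, likely between 800 nM and 12000 nM.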

Compound 3, half-maximal effective concentration: 1930 nM
The estimate for compound 3 lay 1.6-fold (0.19 log units) above the measured number; the range from low to high includes it.
By their numbers in this assay, from the lowest: compounds 3 and 1 (each within the scatter of the next); then compound 2.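

In this assay, phenyl in place of hydrogen on a saturated chain carbon bound to an oxygen on an aromatic ring gives a 1.1-fold lower number from compound 1 to compound 3 (0.02 log units; within the scatter) and so leaves compound 1 and compound 3 indistinguishable. This position therefore takes on 6 more heavy atoms, including a whole aromatic ring, with no change beyond the usual scatter. No available measurement offers an explanation for this result.

Going by these compounds, whether a cyclohexyl ring or a longer chain ending in an amine would fare the same at this place remains open. Also open, on these data alone, is whether phenyl would act alike on the core of compound 2.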